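Aryl ester swap on the shared core: plasma stability

The source may hold more compounds than are shown below. What is called first, only, known or untested is meant among the compounds shown, and "the series" means these compounds.

Measured compounds:
compound 1 `CC(=O)Oc1ccccc1C(=O)O[C@H]1CO[C@H]2[C@@H]1OC[C@H]2OC(=O)c1ccc(O)cc1`: 0.0198 h
compound 2 `CC(=O)Oc1ccccc1C(=O)O[C@H]1CO[C@H]2[C@@H]1OC[C@H]2OC(C)=O`: 0.0095 h
compound 3 `CC(=O)Oc1ccccc1C(=O)O[C@H]1CO[C@H]2[C@@H]1OC[C@H]2OC(=O)c1ccccc1`: 0.0107 h

All three were read in an ADME assay on a cell-free system (plasma, Homo sapiens) for metabolic stability, with Plasma (Rattus norvegicus) as the target, read by HPLC, at pH 7.4; a lower number here means that the compound disappears faster, a higher number that the compound lasts longer. Compound 1 stands highest of the three numbers; its nearest neighbour is compound 3, with a 1.9-fold lower number from compound 1 to compound 3 (0.27 log units; within the scatter), and its furthest is compound 2, with a 2.1-fold lower number from compound 1 to compound 2 (0.32 log units; beyond the scatter), a modest step. Between the two smaller esters, a 1.1-fold higher number from compound 2 to compound 3 (0.05 log units; within the scatter), so the whole set sits in a narrow band.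

Compound 4 `CC(=O)Nc1cccc(C(=O)O[C@@H]2CO[C@H]3[C@@H]2OC[C@@H]3OC(=O)c2ccccc2OC(C)=O)c1` differs from compound 1 in one place: 3-acetamidophenyl in place of 4-hydroxyphenyl on a carbonyl carbon. For the measured compounds named here, the step that bears most on this change is the one from compound 1 to compound 3, where the hydroxy on the aromatic carbon was taken away and the number fell only within the scatter. The step from compound 1 to compound 2 shows that even a switch from an aryl group to methyl on that carbonyl carbon moves the number only modestly. Compound 4 keeps an aryl ester with one hydrogen-bond donor, so in this assay compound 4 is expected to sit close to compound 1, with a step of a 1.4-fold lower number from compound 1 to compound 4 (0.15 log units; within the scatter), most likely within the scatter and slightly downward. The estimate for compound 4 is 0.014 h, between 0.007 h and 0.028 h.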

Compound 4, half-life: 0.0583 h
For compound 4 the middle estimate is 4.2-fold (0.62 log units) below the measured one; the measured number lies above the stated range.
By their numbers in this assay, from the lowest: compounds 2, 3 and 1 (each within the scatter of the next, the first and the last beyond it); then compound 4.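

In this assay the position on the carbonyl carbon, where 4-hydroxyphenyl, phenyl and methyl had given numbers in a narrow band, responds clearly to 3-acetamidophenyl, with a 2.9-fold higher number from compound 1 to compound 4 (0.47 log units; beyond the scatter) for that exchange. Against the other two compounds the rise is also beyond the scatter, with a 5.4-fold higher number from compound 3 to compound 4 (0.74 log units; beyond the scatter) on adding acetamido to the phenyl ester and a 6.1-fold higher number from compound 2 to compound 4 (0.79 log units; beyond the scatter) on replacing the methyl, so compound 4 stands highest of the four and an aryl ester alone does not account for its place, as compound 1 and compound 3 also carry one. Nothing at hand gives a reason for this rise.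

As far as these compounds go, whether the rise belongs to the acetamido group as a whole or only to part of it stays open, and an amine or a carboxylic acid in its place on the phenyl ring would test how much of the change survives without the acetyl unit. Also open, from the compounds shown here alone, is how a longer acyl chain on the same nitrogen would behave at this position on the shared core.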